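From Phenyl to Phenoxy: Expecting an Unchanged Maximal Response

The source may hold more compounds than are shown below. What is called first, only, known or untested is meant among the compounds shown, and "the series" means these compounds.

Of the compounds shown here, three built on one shared core have been tested in a functional assay for agonist activity at growth hormone secretagogue receptor type 1 (Homo sapiens), read by FLIPR; a higher number here means a larger maximal response, a lower number a smaller maximal response. Compound 1 `COc1ccc(N2C[C@@H](C)N[C@@H](C)C2)cc1NS(=O)(=O)c1ccc(-c2ccccc2)cc1` gives 1. Compound 3 `COc1ccc(N2C[C@@H](C)N[C@@H](C)C2)cc1NS(=O)(=O)c1cccc(-c2ccccc2)c1` gives 1 in this assay, level with compound 1 at the digits shown, so these two together hold the highest numbers of the three. Compound 2 `COc1ccc(N2C[C@@H](C)N[C@@H](C)C2)cc1NS(=O)(=O)c1ccc(-c2cccs2)cc1F` gives 0.9 in this assay, a shade lower than compound 1 yet still within the scatter of repeated measurements, so no real difference among the three can be claimed; all reach essentially the full reference response.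

Compound 4 `COc1ccc(N2C[C@@H](C)N[C@@H](C)C2)cc1NS(=O)(=O)c1ccc(Oc2ccccc2)cc1` has not yet been measured. It differs from compound 1 by one change: phenoxy in place of phenyl on an aromatic carbon. Among the measured compounds shown here, no pair of measured compounds differing in a single place is available to gauge such a change. The step expected in this assay is a number 0.10 lower from compound 1 to compound 4 (within the scatter), small and probably within the scatter, with at most a slight fall. Compound 4 is estimated to give 0.9 in this assay, within a range from 0.7 to 1.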

Compound 4, intrinsic activity: the largest response reached, as a fraction of the reference agonist's: 0.9
For compound 4 middle estimate and measured number coincide at the digits printed; low and high end bracket the measured number.
By their numbers in this assay, from the lowest: compounds 2, 4, 1 and 3 (each within the scatter of the next).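

In this assay, putting phenoxy in place of phenyl on an aromatic carbon para to a large group gives a number 0.10 lower from compound 1 to compound 4 (within the scatter). Among the compounds shown here, this is the first comparison that differs in one place only, and it shows that this position accepts an added oxygen, and with it a hydrogen-bond acceptor, with no real change in maximal response. No measurement at hand explains this result.

This single step cannot show whether other linked aromatic groups, such as benzyl or benzyloxy, would give the same outcome. It also leaves open whether the maximal response would hold with a group of a different kind at this position, such as an amine or a carboxylic acid.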